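A few compounds are considered here, and "the series" means these few. Any claim that something is new, unique, unknown or untested is made for them only; others in the source may bear on it.

Measured so far:
compound 1, `Cc1cc(NC(=O)Nc2ccc(N(C)C)cc2)c2ccccc2n1` — > 25000 nM
compound 2, `Cc1cc(NC(=O)Nc2cccc3nsnc23)c2ccccc2n1` — > 25000 nM

In an ADME assay on Raji cells (Homo sapiens) for cytotoxicity, with a stated time of 72 h (a higher number here means that more compound is needed for the effect, a lower number that less compound is needed), compound 1 gives > 25000 nM, which is a limit of the assay and not a number. Compound 2 likewise gives > 25000 nM in this assay, also a limit. Going by the values given here, compound 1 thus stands at the limit of > 25000 nM in this assay, at which 2 of the 2 values shown sit, with no number to place it against, and no step between measured compounds differing in one place is available.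

Compound 3, `Cc1cc(NC(=O)Nc2ccc(N)cc2)c2ccccc2n1`, is not yet measured in this assay. It differs from compound 1 as follows: amino in place of dimethylamino on an aromatic carbon. With every measured value at the limit, no step size can be read from the series, and no step beyond the scatter is expected from amino in place of dimethylamino on an aromatic carbon. Compound 3 is estimated at 30000 nM, in a range from 10000 nM to 100000 nM, most likely reported again as a limit. The expected step is a step that the limit leaves unreadable from compound 1 to compound 3, within scatter.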

Compound 3, half-maximal effective concentration: > 25000 nM
Compound 3 was reported as a limit; the forecaster's own chance of this, stated with the estimate: 85%; the middle value lies beyond the limit too.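

No step can be read from compound 1 to compound 3 in this assay, as both values are limits and not numbers: the limit of > 25000 nM in this assay, at which 3 of the 3 values shown sit.

The compounds shown leave open what amino in place of dimethylamino on an aromatic carbon does to the half-maximal effective concentration, and whether any compound on this core gives a measurable number.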